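A few compounds are considered here, and "the series" means these few. Any claim that something is new, unique, unknown or untested is made for them only; others in the source may bear on it.

Two measured compounds share one core, to which a six-membered aromatic ring of carbon only bearing a hydroxy group is attached. Compound 1 `COc1ccc(-n2c(N)nc3ccccc32)c(O)c1` carries a methoxy group on that ring, and in an ADME assay on microsomes from liver (Homo sapiens) for metabolic stability, read by LC-MS, using NADPH, with a stated time of 60 min, tested at 1 uM (a lower number here means slower removal, a higher number faster removal of the compound), compound 1 gives 14 uL/min. Compound 2 `Cc1ccc(-n2c(N)nc3ccccc32)c(O)c1` carries a methyl group in place of the methoxy, and in this assay compound 2 gives 11 uL/min. Among the measured compounds shown here, the change from methoxy to methyl on the aromatic carbon brought a 1.3-fold lower number from compound 1 to compound 2 (0.10 log units; within the scatter), so on the numbers so far compound 2 sits alongside compound 1, with nothing to separate the two.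

Compound 3 `Nc1nc2ccccc2n1-c1ccccc1O` is the next step: hydrogen in place of methyl on an aromatic carbon. The methyl that leaves sits meta to the hydroxy group and para to a large group. For the measured compounds named here, the only measured step that bears on this is a 1.3-fold lower number from compound 1 to compound 2 (0.10 log units; within the scatter), which was within the scatter, and it concerned a different exchange on the same carbon. A small change is therefore expected, a 1.2-fold lower number from compound 2 to compound 3 (0.09 log units; within the scatter), leaning slightly toward a lower number. For compound 3 in this assay the estimate is 9 uL/min, with a range from 5 uL/min to 18 uL/min.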

Compound 3, intrinsic clearance in a liver preparation (reported as CLH), per the amount of preparation that the assay uses: < 7 uL/min
Compound 3: only a limit was reported (the forecaster's own chance of this, stated with the estimate: 5%); middle value at least 1.2-fold (0.10 log units) away from the limit.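

In this assay compound 3 gives < 7 uL/min, which is a limit of the assay and not a number. Removing the group from this carbon altogether, so that only hydrogen remains, gives an at least 1.5-fold lower number from compound 2 to compound 3 (0.19 log units; that floor lies within the scatter), and measured against the methoxy group the same position gives an at least 2.0-fold lower number from compound 1 to compound 3 (0.30 log units; that floor lies within the scatter). Each of these steps is only a floor, so the true gap could be wider, which the earlier pair could not suggest, as it only swapped one group for another on this carbon; yet both floors lie within the scatter, so compound 3 is not firmly set apart from compound 1 or compound 2.

The compounds shown carry only methoxy, methyl or hydrogen on this carbon, so it stays open how a fluorine, a chlorine or an amine there would read. Going by these compounds, the actual number for compound 3 also stays unknown, as does whether the same exchange on another carbon of this ring would give a similar result.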